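A Methoxy Group Added to the Triazole Phenyl Ring

The compounds below may be only part of what the source reports. "The series", "measured", "known", "first", "only" and "open" are said of these compounds alone.

Within the data shown here, compound 2 `C=C1C(=O)[C@]23C[C@@]1(O)CC[C@H]2c1ccc(O)c(C)c1[C@@H]3Cn1cc(-c2ccccc2)nn1` is the only compound measured so far that gives a number in a functional assay on A549 cells (Homo sapiens) for cytotoxicity, read by MTT assay, with a stated time of 4 days; on this read-out lower numbers stand for stronger inhibition and higher numbers for weaker inhibition: compound 2 gives 1160 nM. Compound 1 `C=C1C[C@]23C[C@@]1(O)CC[C@H]2c1ccc(OS(=O)(=O)c2ccc(C)cc2)c(C)c1[C@@H]3Cn1cc(-c2ccc(Br)cc2)nn1` reaches only a limit of the assay in this assay, where compound 1 gives > 20000 nM. Compound 3 `C=C1C[C@]23C[C@@]1(O)CC[C@@H]2c1cccc(C)c1[C@@H]3Cn1cc(-c2ccccn2)nn1` likewise reaches only a limit in this assay, where compound 3 gives > 20000 nM. Compound 2 thus stands alone with a number, while the two other values sit at the limit of > 20000 nM in this assay, at which 2 of the 3 values shown sit. Compound 4 `C=C1C(=O)[C@]23C[C@@]1(O)CC[C@H]2c1ccc(O)c(C)c1[C@@H]3Cn1cc(-c2ccc(OC)cc2)nn1` has not yet been measured. It differs from compound 2 in one place: methoxy in place of hydrogen on an aromatic carbon, para to a large group; cut one bond further out, the difference reads phenyl to 4-methoxyphenyl. Among the measured compounds shown here, no measured pair here differs in a single place, so no step size between measured compounds is known. Compound 4 is expected to show a step of a 1.0-fold higher number from compound 2 to compound 4 (0.01 log units; within the scatter), within the usual scatter in either direction. Compound 4 is therefore estimated at 1200 nM in this assay, with a range from 400 nM to 4000 nM.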

Compound 4, half-maximal inhibitory concentration: 1250 nM
Compound 4: middle estimate off by 1.0-fold (0.02 log units), on the low side, within the range that was stated.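

Among these compounds, this is the first step between two measured compounds that differ in one place, and it gives the position a size: in this assay, methoxy in place of hydrogen on an aromatic carbon, para to a large group, gives a 1.1-fold higher number from compound 2 to compound 4 (0.03 log units; within the scatter). The change from phenyl to 4-methoxyphenyl therefore stays within the scatter, so this one added group leaves the read-out where it was. Among the compounds shown here, none of the earlier compounds formed such a pair, so this position had no measured step until now.

From the compounds shown here alone, whether an amine, a carboxylic acid or a longer alkoxy chain in the same place would also leave the read-out unmoved remains open. The two other compounds differ from these in more than one place and give only a limit, so they do not settle the matter: the limit of > 20000 nM in this assay, at which 2 of the 4 values shown sit.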